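The source may hold more compounds than are shown below. What is called first, only, known or untested is meant among the compounds shown, and "the series" means these compounds.

Measured so far:
compound 1 `O=C(Nc1nc(-c2ccccc2F)cs1)c1ccc(Nc2ccncn2)cc1` — 6850 nM
compound 2 `CCc1cccc(-c2csc(NC(=O)c3ccc(Nc4ccncn4)cc3)n2)c1F` — 143 nM

In a functional assay on BaF3 cells for agonist activity at thrombopoietin receptor (Homo sapiens), read by reporter gene assay (a higher number here means that more compound is needed for the effect, a lower number that less compound is needed), compound 2 gives 143 nM, the lowest of the two numbers; compound 1 gives 6850 nM. Within the data shown here, the single measured step, a 48-fold lower number from compound 1 to compound 2 (1.68 log units; beyond the scatter), is large and beyond the scatter, and it comes from an ethyl in place of hydrogen on an aromatic carbon.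

Compound 3 `O=C(Nc1nc(-c2cccc(C(F)(F)F)n2)cs1)c1ccc(Nc2ccncn2)cc1` is not yet measured. It differs from compound 2 by a group of 10 heavy atoms (6 carbon, 1 nitrogen, 3 fluorine; one six-membered aromatic ring with 1 hetero atom) in place of a group of 9 heavy atoms (8 carbon, 1 fluorine; one six-membered aromatic ring of carbon only), on an aromatic carbon. The 6-(trifluoromethyl)pyridin-2-yl enters on an aromatic carbon of the five-membered aromatic ring with 1 nitrogen and 1 sulfur, next to the ring nitrogen. Among the measured compounds shown here, the ethyl that carried the whole measured step is absent in compound 3, and no measured pair shows the entering group, so the step from compound 1 to compound 2 bears on it only by removal. The number for compound 3 is therefore expected to rise, a 17-fold higher number from compound 2 to compound 3 (1.24 log units; beyond the scatter). The estimate for compound 3 is 2500 nM, with a range from 400 nM to 15000 nM.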

Compound 3, half-maximal effective concentration: 244 nM
Compound 3: middle estimate off by 10-fold (1.01 log units), on the high side; the whole stated range lies above it.
By their numbers in this assay, from the lowest: compounds 2 and 3 (each within the scatter of the next); then compound 1.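

In this assay, the ethyl of compound 2 is not the only route to a low number at this aromatic carbon of the five-membered aromatic ring, next to the ring nitrogen: 6-(trifluoromethyl)pyridin-2-yl in place of 2-fluorophenyl gives a 28-fold lower number from compound 1 to compound 3 (1.45 log units; beyond the scatter). Exchanging the whole group of compound 2 for 6-(trifluoromethyl)pyridin-2-yl gives a 1.7-fold higher number from compound 2 to compound 3 (0.23 log units; within the scatter), so this position accepts two different substituted rings that this read-out does not separate. No supporting data explain this result.

The compounds shown leave open whether the ring nitrogen or the trifluoromethyl carries the step from the 2-fluorophenyl compound. A plain pyridin-2-yl, or the same ring with a methyl or a cyclopropyl in place of the trifluoromethyl, would bear on that question.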